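Aryl amide change from compound 3 to compound 4

A few compounds are considered here, and "the series" means these few. Any claim that something is new, unique, unknown or untested is made for them only; others in the source may bear on it.

In an in vitro ADME assay on microsomes from liver (Mus musculus) for pharmacokinetics, read by LC-MS, with a stated time of 10 min, tested at 1 uM (a higher number here means faster removal of the compound, a lower number slower removal), compound 1 `COc1ccc(NC(=O)[C@H]2CN(C)C[C@@H]2c2ccc(/C=C/C(=O)Nc3ccccc3N)cc2)cc1` gives 54 mL/min/kg and compound 2 `CC(C)c1ccc(NC(=O)[C@H]2CN(C)C[C@@H]2c2ccc(/C=C/C(=O)Nc3ccccc3N)cc2)cc1` gives 54 mL/min/kg. Compound 3 `CN1C[C@H](C(=O)Nc2ccc(Br)cc2)[C@@H](c2ccc(/C=C/C(=O)Nc3ccccc3N)cc2)C1` gives 16 mL/min/kg, the lowest of the three numbers. Compound 4 `CN1C[C@H](C(=O)Nc2ccc(F)c(F)c2)[C@@H](c2ccc(/C=C/C(=O)Nc3ccccc3N)cc2)C1` is unmeasured and differs from it as follows: 3,4-difluorophenyl in place of 4-bromophenyl on an amide-type nitrogen. The relevant steps are a 3.4-fold lower number from compound 1 to compound 3 (0.53 log units; beyond the scatter) and a 3.4-fold lower number from compound 2 to compound 3 (0.53 log units; beyond the scatter), both beyond the scatter, while no change at the digits printed from compound 1 to compound 2 (within the scatter) stays within it. Among the measured compounds shown here, no compound with fluorine has been measured, so this evidence is indirect. Compound 3 holds the low end through a 3.4-fold lower number from compound 2 to compound 3 (0.53 log units; beyond the scatter), so a modest rise in this assay is expected on leaving the bromo group. The expected change is a 1.6-fold higher number from compound 3 to compound 4 (0.21 log units; within the scatter). For compound 4 the estimated clearance is 26 mL/min/kg, with an expected range of 11 mL/min/kg to 60 mL/min/kg.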

Compound 4, clearance: 46 mL/min/kg
The estimate for compound 4 lay 1.8-fold (0.25 log units) below the measured number; the range from low to high includes it.
By their numbers in this assay, from the lowest: compound 3; then compounds 4, 1 and 2 (each within the scatter of the next).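

With a 2.9-fold higher number from compound 3 to compound 4 (0.46 log units; beyond the scatter) in this assay, the low number does not carry over to 3,4-difluorophenyl on the amide-type nitrogen, so a halogen on this aryl group is not enough to hold it. Among the compounds shown here, the new group instead falls in with 4-methoxyphenyl and 4-isopropylphenyl, with a 1.2-fold lower number from compound 1 to compound 4 (0.07 log units; within the scatter) and a 1.2-fold lower number from compound 2 to compound 4 (0.07 log units; within the scatter), which leaves 4-bromophenyl as the only one of the four groups set apart. Open, from the compounds shown here alone, is whether a chloro group or a nitrile in place of the bromo group keeps the low number. No measurement shown gives a reason for this separation.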